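A few compounds are considered here, and "the series" means these few. Any claim that something is new, unique, unknown or untested is made for them only; others in the source may bear on it.

Measured compounds:
compound 1 `Cc1c(Cl)cccc1CCCCOc1ccc(C#Cc2cccc3c(CCCC(=O)O)c(C)n(CCCCC(=O)O)c23)cc1` gives 30 nM
compound 2 `Cc1c(Cl)cccc1CCCCOc1ccc(C#Cc2cccc3c(CC(=O)O)c(C)n(CCCCC(=O)O)c23)cc1` gives 248 nM
compound 3 `Cc1c(Cl)cccc1CCCCOc1ccc(C#Cc2cccc3c(CC(=O)O)c(C)n(CC(=O)O)c23)cc1` gives 0.89 nM

These numbers come from a functional assay on HEK293 cells for antagonist activity at cysteinyl leukotriene receptor 2 (Homo sapiens), read by fluorescence and calcium flux, with stated times of 30 min and 1 h (on this read-out higher numbers stand for weaker inhibition and lower numbers for stronger inhibition), in which compound 3 gives the lowest of the three. Compound 4 `Cc1c(Cl)cccc1CCCCOc1ccc(C#Cc2cccc3c(CC(=O)O)c(C)n(CCCC(=O)O)c23)cc1` is not yet measured; it differs from compound 3 by 2-carboxyethyl in place of carboxy on a saturated chain carbon bound to an aromatic nitrogen. The same kind of change is already measured once: compound 1 differs from compound 2 by 2-carboxyethyl in place of carboxy on a saturated chain carbon bound to an aromatic carbon, a step of an 8.3-fold lower number from compound 2 to compound 1 (0.92 log units; beyond the scatter). The two places are not the same word for word, one being on a saturated chain carbon bound to an aromatic carbon and the other on a saturated chain carbon bound to an aromatic nitrogen, so this is the same kind of change, not the same. The two cores also differ, compound 3 against compound 2 by carboxy in place of 3-carboxypropyl on a saturated chain carbon bound to an aromatic nitrogen, a step of a 280-fold lower number from compound 2 to compound 3 (2.45 log units; beyond the scatter). Because a 280-fold lower number from compound 2 to compound 3 (2.45 log units; beyond the scatter) shows the shorter chain at the aromatic nitrogen going with a far lower number, lengthening that chain again in compound 4 is expected to raise the number. The expected step is a 13-fold higher number from compound 3 to compound 4 (1.13 log units; beyond the scatter). Compound 4 is estimated at 12 nM, between 2 nM and 70 nM.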

Compound 4, half-maximal inhibitory concentration: 55 nM
Estimate against measurement, compound 4: 4.6-fold (0.66 log units) below; low and high end bracket the measured number.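

In this assay, replacing carboxy with 2-carboxyethyl does not carry over from one core to another in this series, and the direction of the step even reverses: the same change on two cores in this assay, an 8.3-fold lower number (0.92 log units; beyond the scatter) from compound 2 to compound 1 and a 62-fold higher number (1.79 log units; beyond the scatter) from compound 3 to compound 4, 510-fold (2.71 log units) apart, beyond the scatter of two such steps

Where only the chain on the aromatic nitrogen varies, the number falls as that chain shortens, with a 4.5-fold lower number from compound 2 to compound 4 (0.65 log units; beyond the scatter) and, in the opposite direction of chain change, a 62-fold higher number from compound 3 to compound 4 (1.79 log units; beyond the scatter). These are single pairs, so they show that the step depends on the core but not why, and they do not predict its size on any further core.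

The compounds shown leave open how an amide in place of either carboxy group would read. They also leave open the effect of a chain longer than 3-carboxypropyl on the aromatic nitrogen.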